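This account rests on a few compounds, and the source may have more. Where it says the series, first, only, none or still open, it means among the compounds named here.

Three compounds that share one core and differ only in the group on a saturated chain carbon bound to a sulfur have been tested in a functional assay on HGC-27 cells (Homo sapiens) for inhibition, read by MTT assay, with a stated time of 72 h; a lower number here means a stronger inhibitor, a higher number a weaker inhibitor. Compound 3 `Cc1cc(N2CC[C@@H](C)[C@@H](N(C)c3ncnc4[nH]ccc34)C2)n2nc(SCC3CCCCC3)nc2n1` gives 11500 nM, and compound 2 `Cc1cc(N2CC[C@@H](C)[C@@H](N(C)c3ncnc4[nH]ccc34)C2)n2nc(SCCc3ccccc3)nc2n1` gives 11800 nM, so compound 3 shares the lowest place with compound 2. Compound 1 `Cc1cc(N2CC[C@@H](C)[C@@H](N(C)c3ncnc4[nH]ccc34)C2)n2nc(SCc3nc4ccccc4[nH]3)nc2n1` gives > 100000 nM, which is a limit of the assay and not a number.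

For the measured compounds named here, compound 4 `COc1ccc(CSc2nc3nc(C)cc(N4CC[C@@H](C)[C@@H](N(C)c5ncnc6[nH]ccc56)C4)n3n2)cc1` keeps the core and changes only that group, (4-methoxyphenyl in place of cyclohexyl on a saturated chain carbon bound to a sulfur), with 4-methoxyphenyl in place of cyclohexyl. Going by the values given here, the closest precedent is a 1.0-fold lower number from compound 2 to compound 3 (0.01 log units; within the scatter), where cyclohexyl in place of benzyl made no difference beyond the scatter. Compounds 2 and 3 therefore suggest that a ring carrying no hydrogen-bond donor can be either aromatic or saturated without moving the number much. Compound 1 is the warning against stretching this, since an at least 8.4-fold lower number from compound 1 to compound 2 (0.92 log units; beyond the scatter) and an at least 8.6-fold lower number from compound 1 to compound 3 (0.93 log units; beyond the scatter) show that not every ring group is equivalent. Those two steps leave some risk of a weaker result, so the range is wide and leans upward.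

The estimated change is a 1.1-fold higher number from compound 3 to compound 4 (0.05 log units; within the scatter), which is no step beyond the scatter. Compound 4 is expected at 13000 nM, with an estimated range from 5000 nM to 35000 nM.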

Compound 4, half-maximal inhibitory concentration: 18200 nM
Compound 4: middle estimate off by 1.4-fold (0.15 log units), on the low side, and the stated range covers the measured number.
By their numbers in this assay, from the lowest: compounds 3, 2 and 4 (each within the scatter of the next). At a limit, above all of these: compound 1.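

Compound 4 brings in 4-methoxyphenyl, a group with a hydrogen-bond acceptor and more heavy atoms than cyclohexyl, and in this assay the result stays level with both earlier neighbours: a 1.6-fold higher number from compound 3 to compound 4 (0.20 log units; within the scatter), and a 1.5-fold higher number from compound 2 to compound 4 (0.19 log units; within the scatter). The earlier pair had shown only that a plain aromatic ring and a saturated ring read alike, whereas this position now also accepts an oxygen-bearing aromatic ring with no change beyond the scatter, so the hydrogen-bond acceptor and the extra size make no measurable difference here. The 1H-benzimidazol-2-yl group of compound 1 remains the only one set apart, with an at least 5.4-fold lower number from compound 1 to compound 4 (0.73 log units; beyond the scatter), and that step starts from a limit of the assay, not a number: the limit of > 100000 nM in this assay, at which 1 of the 4 values shown sits.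

The compounds shown do not tell whether the hydrogen-bond donor of the 1H-benzimidazol-2-yl group is what separates compound 1 from the rest, a question that a 4-hydroxyphenyl group on the same chain carbon could address. They also leave open whether any group at this position can bring the number clearly lower, for instance an amine, a carboxylic acid or a simple methyl on the sulfur.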